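Chloro added to the benzyl ring of compound 3

The source may report more compounds than this note shows. Statements on the series, on what has been measured and on what is new or still open speak of the compounds shown alone.

Compound 3 `Cc1cc2c(CC(=O)O)c(C)n(Cc3ccc(S(C)(=O)=O)cc3)c2s1` stands at the top of the three numbers in hand: in an assay on HEK293 cells for displacement of a labelled ligand from prostaglandin D2 receptor 2 (Homo sapiens) (a lower number here means a stronger inhibitor, a higher number a weaker inhibitor), compound 3 gives 1800 nM. Among the compounds with values here, compound 1 `Cc1c(CC(=O)O)c2ccsc2n1S(=O)(=O)c1ccc(S(=O)(=O)N2CCCC2)cc1` gives 390 nM in this assay, and compound 2 `Cc1c(CC(=O)O)c2ccsc2n1Cc1ccc(S(C)(=O)=O)cc1Cl` gives 10 nM; both differ from compound 3 in more than one place, so no single step can be drawn from either. Compound 4 `Cc1cc2c(CC(=O)O)c(C)n(Cc3ccc(S(C)(=O)=O)cc3Cl)c2s1` is not yet measured. It differs from compound 3 by chloro in place of hydrogen on an aromatic carbon. Compound 2 also carries a chloro on its six-membered aromatic ring of carbon only and sits well under compound 3, which is the only ground for expecting a step down. The step expected in this assay is a 5.1-fold lower number from compound 3 to compound 4 (0.71 log units; beyond the scatter), beyond the scatter. Compound 4 is estimated at 350 nM, within 80 nM to 1500 nM.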

Compound 4, half-maximal inhibitory concentration: 330 nM
Beside the measured number, compound 4's estimate is 1.1-fold (0.03 log units) above it; the range from low to high includes it.
By their numbers in this assay, from the lowest: compound 2; then compounds 4 and 1 (each within the scatter of the next); then compound 3.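

In this assay, within the data shown here, chloro in place of hydrogen on an aromatic carbon, ortho to a large group and meta to a methylsulfonyl group, gives a 5.5-fold lower number from compound 3 to compound 4 (0.74 log units; beyond the scatter), the first single-place reading at this position. With that chloro held, one added methyl on the shared core gives a 33-fold higher number from compound 2 to compound 4 (1.52 log units; beyond the scatter), so the methyl step is the larger of the two. Nothing on hand accounts for either step.

Open, as far as these compounds go, is whether fluoro, methoxy or nitrile at the chloro position would match chloro. Also open, from the compounds shown here alone, is whether ethyl in place of that methyl would give a similar step.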